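The compounds below may be only part of what the source reports. "The series", "measured", "known", "first", "only" and "open" are said of these compounds alone.

Among the compounds with values here, compound 1 `O=C(c1cc(-c2cn[nH]c2)on1)N1CCC(Cc2ccccc2)CC1` is the only member of this small set with a number in an ADME assay on the whole organism (Rattus norvegicus, strain Sprague-Dawley) for pharmacokinetics, using cassette dosing, at a dose of 0.5 mg/kg by the intravenous route (a higher number here means faster removal of the compound, a lower number slower removal), where compound 1 gives 71.6 mL/min/kg. Its relative compound 2 `O=C(c1cc(-c2cn[nH]c2)on1)N1CCC(Cc2ccc(F)cc2)CC1` offers no comparison, as the entry for compound 2 reads "not determined" (no result reported). Within the data shown here, no measured step therefore shows how far a structural change moves this read-out. Compound 3 `O=C(c1cc(-c2ccc(=O)[nH]c2)on1)N1CCC(Cc2ccccc2)CC1` keeps the rest of compound 1 and changes one group, on an aromatic carbon of a five-membered aromatic ring with 1 nitrogen and 1 oxygen: a group of 7 heavy atoms (5 carbon, 1 nitrogen, 1 oxygen; one six-membered aromatic ring with 1 hetero atom) in place of a group of 5 heavy atoms (3 carbon, 2 nitrogen; one five-membered aromatic ring with 2 hetero atoms), on an aromatic carbon. With compound 1 at 71.6 mL/min/kg as the sole anchor, a moderate fall in this assay is expected, although a result within the usual scatter would be no surprise. The expected change is a 1.6-fold lower number from compound 1 to compound 3 (0.20 log units; within the scatter). Compound 3 is estimated at 45 mL/min/kg, with an expected range of 20 mL/min/kg to 90 mL/min/kg.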

Compound 3, clearance: 19.3 mL/min/kg
For compound 3 the middle estimate is 2.3-fold (0.37 log units) above the measured one; the measured number lies below the stated range.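

Within the data shown here, the exchange of the 1H-pyrazol-4-yl group, on the aromatic carbon next to the ring oxygen, for the larger six-membered ring group gives the first measured step at this position, a 3.7-fold lower number from compound 1 to compound 3 (0.57 log units; beyond the scatter), in this assay. So this position can move the read-out beyond the usual scatter, and it does so with no change in net charge or in the counts of hydrogen-bond donors and acceptors of the two groups. No measurement shown here explains why the number falls.

Whether the same exchange lowers the number on the fluorinated relative, compound 2, cannot be read, as that compound has no value. Also open, going by these compounds, is how a plain phenyl ring, a pyridine or a carboxylic acid at this carbon would compare with compound 3.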